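This account rests on a few compounds, and the source may have more. Where it says the series, first, only, none or still open, it means among the compounds named here.

Working notes on the series. Compound 3 `Cc1cccc(-n2nncc2CN2C(=O)C3(C(C#N)=C(N)Oc4c(N)cc5nc6ccccc6nc5c43)c3ccccc32)c1` is known in an ADME assay on HUVEC cells (Homo sapiens) for antiproliferative activity, read by MTT assay, with a stated time of 48 h (a higher number here means a weaker inhibitor, a lower number a stronger inhibitor), only as a limit: compound 3 gives > 50000 nM. Compound 2 `Cc1ccccc1-n1nncc1CN1C(=O)C2(C(C#N)=C(N)Oc3c(N)cc4nc5ccccc5nc4c32)c2ccccc21` likewise gives only the limit > 50000 nM in this assay. Compound 1 `Cc1ccc(-n2nncc2CN2C(=O)C3(C(C#N)=C(N)Oc4c3c3nc5ccccc5nc3c3ccccc43)c3ccccc32)c(C)c1` gives only the limit > 50000 nM in this assay. Every value shown sits at one limit (the limit of > 50000 nM in this assay, at which 3 of the 3 values shown sit), so the step that the two limits leave unreadable from compound 2 to compound 3 has no readable size. Compound 4 `CCc1ccccc1-n1nncc1CN1C(=O)C2(C(C#N)=C(N)Oc3c(N)cc4nc5ccccc5nc4c32)c2ccccc21` differs from compound 3 by 2-ethylphenyl in place of 3-methylphenyl on an aromatic nitrogen. Among the compounds with values here, the only measured step that bears on this change, from compound 2 to compound 3, was unreadable, so no step beyond the scatter is expected and the likeliest outcome is again a limit. Compound 4 is therefore expected to give 80000 nM in this assay, within 30000 nM to 300000 nM, which means an expected step that the limit leaves unreadable from compound 3 to compound 4.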

Compound 4, half-maximal inhibitory concentration: > 50000 nM
Compound 4: no number, only a limit; the forecaster's own chance of this, stated with the estimate: 85%; the middle value does not contradict the limit.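

Compound 4, like compound 2 and compound 3, gives only a limit in this assay, so no step among these three compounds can be read: the limit of > 50000 nM in this assay, at which 4 of the 4 values shown sit.

The compounds shown leave open whether 2-methylphenyl, 3-methylphenyl and 2-ethylphenyl differ at all in this read-out.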